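Swapping bromo for chloro on a thiazole hydrazone scaffold

The source may hold more compounds than are shown below. What is called first, only, known or untested is meant among the compounds shown, and "the series" means these compounds.

Compound 1 `O=C(CSc1ncccn1)N/N=c1/scc(-c2ccc(Br)cc2)n1-c1ccccc1` gives 67.6% in a functional assay on C6 cells (Rattus norvegicus) for cytotoxicity, read by MTT assay, with a stated time of 24 h, tested at 100 ug/mL (a higher number here means a weaker effect of the compound at the concentration tested, a lower number a stronger effect), the highest of the three numbers here. Compound 2 `Cn1nnnc1SCC(=O)N/N=c1/scc(-c2ccc(C#N)cc2)n1-c1ccccc1` gives 30.9% and compound 3 `O=C(CSc1nnnn1-c1ccccc1)N/N=c1/scc(-c2ccc(Br)cc2)n1-c1ccccc1` gives 24.3%; the step of a number 43.3 percentage points lower from compound 1 to compound 3 (beyond the scatter) shows how strongly a change at the sulfur-linked ring can move the read-out. Compound 4 `O=C(CSc1ncccn1)N/N=c1/scc(-c2ccc(Cl)cc2)n1-c1ccccc1` differs from compound 1 in another place: chloro in place of bromo on an aromatic carbon. For the measured compounds named here, none of the measured steps touches this halogen, so the comparison of compound 1 with compound 3 gives no guide to it, and the step of a number 0.4 percentage points higher from compound 1 to compound 4 (within the scatter) is expected to stay within the scatter. For compound 4 the estimate is 68%, between 50% and 85%.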

Compound 4, a percentage reported as activity, at one concentration (the size of the read-out at that concentration, not a potency): 45.5%
Estimate against measurement, compound 4: 22.5 percentage points above, outside the stated range (below it).
By their numbers in this assay, from the lowest: compounds 3 and 2 (each within the scatter of the next); then compound 4; then compound 1.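

Swapping one halogen for another in the 4-bromophenyl to 4-chlorophenyl change moves the read-out in this assay by a number 22.1 percentage points lower from compound 1 to compound 4 (beyond the scatter), so this aromatic carbon matters as well. The earlier compounds shown here showed such a shift only with a change at the sulfur-linked ring. Nothing available explains why this halogen swap has this effect.

Open, on these data alone, is how fluoro or methoxy at the same place would read. Also open, as far as these compounds go, is whether chloro in place of bromo would give a similar step with the 1-phenyl-1H-tetrazol-5-yl group of compound 3 on the sulfur.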